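The source may hold more compounds than are shown below. What is called first, only, known or untested is meant among the compounds shown, and "the series" means these compounds.

Compound 2 `COc1ccc2c(=O)c(/C=C/C(=O)NCc3ccc(F)cc3F)coc2c1` and compound 1 `COc1ccc2c(=O)c(/C=C/C(=O)NCc3cccc(F)c3)coc2c1` share one core and differ only in the group on the saturated chain carbon bound to the amide-type nitrogen. In an ADME assay on HepG2 2.2.15 cells (Homo sapiens) for cytotoxicity, read by MTT assay, with stated times of 48 h and 9 days (a lower number here means that less compound is tolerated, a higher number that more compound is tolerated), compound 1 gives 475000 nM, while compound 2 gives 79300 nM. Among the compounds with values here, that is a 6.0-fold lower number from compound 1 to compound 2 (0.78 log units; beyond the scatter), so compound 2 stands with the lowest of the two numbers known so far, and its nearest neighbour is compound 1.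

Compound 3 `COc1ccc2c(=O)c(/C=C/C(=O)Nc3ccc(C)cc3)coc2c1` takes a different turn: 4-methylphenyl in place of 2,4-difluorobenzyl on an amide-type nitrogen. Within the data shown here, the one measured step, from compound 1 to compound 2, moved the fluorine pattern on a benzyl group and was modest in size; it does not tell how losing the chain carbon and the fluorines, and placing an aryl group straight on the nitrogen, will show up in this assay. With so little to lean on, the expectation is a step of a 1.9-fold higher number from compound 2 to compound 3 (0.28 log units; within the scatter), pointing back toward the number of compound 1 but not with confidence beyond the scatter.

For compound 3 the estimate is 150000 nM, with a range from 50000 nM to 450000 nM.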

Compound 3, half-maximal cytotoxic concentration: 979000 nM
The estimate for compound 3 lay 6.5-fold (0.81 log units) below the measured number; measured number outside the range, above it.
By their numbers in this assay, from the lowest: compound 2; then compound 1; then compound 3.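

In this assay, putting 4-methylphenyl in place of 2,4-difluorobenzyl on the amide-type nitrogen gives a 12-fold higher number from compound 2 to compound 3 (1.09 log units; beyond the scatter), while putting it in place of 3-fluorobenzyl gives a 2.1-fold higher number from compound 1 to compound 3 (0.31 log units; beyond the scatter). The earlier step showed only that changing the fluorine pattern on a benzyl group can lower the number, whereas these steps show that leaving the benzyl series for 4-methylphenyl gives the highest number of the three, meaning that more of the compound is tolerated, from either benzyl starting point. The size of the step depends strongly on which benzyl group is replaced, and nothing available explains these shifts.

The loss of the chain carbon, the loss of fluorine and the arrival of methyl all happen in the same change, so the compounds shown cannot say which of these matters, or whether they matter only in combination. From the compounds shown here alone, a 4-methylbenzyl group on this nitrogen would keep the chain carbon along with the methyl, and an unsubstituted phenyl would remove both the methyl and the fluorine, so how either would read here remains open.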